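A Halogen Shift from Compound 2 to Compound 4

This account rests on a few compounds, and the source may have more. Where it says the series, first, only, none or still open, it means among the compounds named here.

Of the compounds shown here, three have been measured so far in a functional assay on Jurkat cells (Homo sapiens) for cytotoxicity, read by luminescence and CellTiter-Glo, with a stated time of 3 days; on this read-out higher numbers stand for weaker inhibition and lower numbers for stronger inhibition. Compound 1 `N#Cc1cc(Cl)ccc1NC(=O)c1ccc2cccnc2c1O` gives 170 nM in this assay. Compound 2 `O=C(Nc1cc(C(F)(F)F)cc(C(F)(F)F)c1)c1cc(Br)ccc1O` gives 350 nM in this assay. Compound 3 `O=C(Nc1ccc(C(F)(F)F)cc1)c1cc(Cl)c(-c2ccccc2)cc1O` gives 1160 nM in this assay. Among these three numbers compound 2 stands second highest: its gap to compound 1, which lies lower, is beyond the usual scatter, and so is its larger gap to compound 3, which lies higher.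

Compound 4 `O=C(Nc1cc(C(F)(F)F)cc(C(F)(F)F)c1)c1ccc(Cl)cc1O` has not yet been measured in this assay. It differs from compound 2 in one place: 4-chloro-2-hydroxyphenyl in place of 5-bromo-2-hydroxyphenyl on a carbonyl carbon. Both groups that leave and enter carry one hydroxyl and one halogen on one six-membered aromatic ring of carbon only, with the same count of heavy atoms, donors and acceptors, so the change is a shift of the halogen and its identity rather than a change in size.

Among the measured compounds shown here, no pair of measured compounds shows this kind of step, so its size is uncertain. The account expects a small step from compound 2 to compound 4, if any, not clearly beyond the scatter, with a slight lean toward a higher number: a 1.3-fold higher number from compound 2 to compound 4 (0.11 log units; within the scatter). For compound 4 the estimate in this assay is 450 nM, within a range from 150 nM to 1400 nM.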

Compound 4, half-maximal inhibitory concentration: 570 nM
For compound 4 the middle estimate is 1.3-fold (0.10 log units) below the measured one, and the stated range covers the measured number.
By their numbers in this assay, from the lowest: compound 1; then compounds 2 and 4 (each within the scatter of the next); then compound 3.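

In this assay, among the compounds shown here, the exchange of 5-bromo-2-hydroxyphenyl for 4-chloro-2-hydroxyphenyl on a carbonyl carbon gives a 1.6-fold higher number from compound 2 to compound 4 (0.21 log units; within the scatter), and this is the first step that can be read between compounds differing in one place. It shows that, with everything else in compound 2 held fixed, this place can take a different halogen in a different ring position without a change that stands clear of the scatter, so this one pair gives no sign that the read-out depends on which of these two groups is present. No measurement is at hand that would bear on why the step has this size.

The compounds shown leave open how the identity of the halogen and its ring position would each count alone, as compound 2 and compound 4 change both at once. They also leave open whether a group of another kind in place of the halogen, such as an amine or a carboxylic acid, would stay as close to compound 2 as the chlorine of compound 4 does.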